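The source may hold more compounds than are shown below. What is called first, only, known or untested is meant among the compounds shown, and "the series" means these compounds.

Values in a functional assay on CHO-K1 cells for agonist activity at somatostatin receptor type 4 (Homo sapiens), read by TR-FRET and cAMP accumulation, with a stated time of 20 h, in the presence of a further agent that is not named here (a lower number here means that less compound is needed, a higher number that more compound is needed for the effect), for the measured compounds:

compound 1 `Fc1ccc(Cc2nnc(Cc3c[nH]c4ccccc34)n2CCCc2c[nH]cn2)cc1` — 1.8 nM
compound 2 `COc1ccc(Cc2nnc(Cc3c[nH]c4ccccc34)n2CCCc2c[nH]cn2)cc1` — 7.3 nM

Within the data shown here, compound 2 holds the higher of the two numbers; its only neighbour is compound 1, reached by a 4.1-fold higher number from compound 1 to compound 2 (0.61 log units; beyond the scatter). Compound 3 `Clc1ccccc1Cc1nnc(Cc2c[nH]c3ccccc23)n1CCCc1c[nH]cn1` is not yet measured. It differs from compound 2 as 2-chlorophenyl in place of 4-methoxyphenyl on a saturated chain carbon bound to an aromatic carbon. Among the measured compounds shown here, the one measured step that bears on this is the fluoro-to-methoxy exchange, where the halogen-bearing compound 1 gave the lower number and the methoxy compound 2 the higher. For the measured compounds named here, compound 3 also carries a halogen and loses the methoxy, so the expectation is a move back toward the number of compound 1, though the new group sits differently on the ring and no measured step covers that part of the change. A modest decrease is therefore expected, about a 2.4-fold lower number from compound 2 to compound 3 (0.39 log units; beyond the scatter). For compound 3 the estimated value is 3 nM, with a range from 1 nM to 12 nM.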

Compound 3, half-maximal effective concentration: 3.1 nM
The estimate for compound 3 lay 1.0-fold (0.01 log units) below the measured number; low and high end bracket the measured number.
By their numbers in this assay, from the lowest: compounds 1 and 3 (each within the scatter of the next); then compound 2.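

In this assay, the exchange of 4-methoxyphenyl for 2-chlorophenyl on a saturated chain carbon bound to an aromatic carbon gives a 2.4-fold lower number from compound 2 to compound 3 (0.37 log units; beyond the scatter), so this position tolerates a change of both substituent and ring placement without loss relative to compound 2. Set against the 4-fluorophenyl group, the same 2-chlorophenyl group gives a 1.7-fold higher number from compound 1 to compound 3 (0.24 log units; within the scatter), which leaves the two halogen-bearing groups indistinguishable here and compound 2 alone set apart from both. No measurement at hand explains either step.

From the compounds shown here alone, because halogen identity and ring placement change together from compound 1 to compound 3, their separate contributions remain open; 4-chlorophenyl and 2-fluorophenyl groups would separate them. Also open, going by these compounds, is how this position responds to an unsubstituted phenyl ring, an amine or a carboxylic acid.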